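The compounds below may be only part of what the source reports. "The series", "measured", "known", "first", "only" and "open" are said of these compounds alone.

Compound 1 `O=C(NCCCCl)Nc1ccc(I)cc1` carries a (3-chloropropyl)amino group on its carbonyl carbon and a iodo group on its aromatic ring. In a functional assay on M21 cells (Homo sapiens) for antiproliferative activity, with a stated time of 48 h (on this read-out higher numbers stand for weaker inhibition and lower numbers for stronger inhibition), compound 1 gives only a limit, > 100000 nM, and no number. Compound 2 `CC(C)(C)c1ccc(NC(=O)NCCCCl)cc1`, in which tert-butyl replaces iodo on the aromatic carbon, gives 35000 nM in this assay, which is an at least 2.8-fold lower number from compound 1 to compound 2 (0.45 log units; beyond the scatter). Compound 3 `CCCCC(OC)c1cccc(NC(=O)CCCl)c1` also sits at a limit, > 100000 nM, so (the limit of > 100000 nM in this assay, at which 2 of the 3 values shown sit), and compound 1 stands among the weakest values shown.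

Compound 4 `C=CC(=O)Nc1ccc(I)cc1` differs from compound 1 by vinyl in place of (3-chloropropyl)amino on a carbonyl carbon. No measured step touches the carbonyl carbon: the one step shown, from compound 1 to compound 2, changes only the aromatic substituent, so it offers no direct guide to the size or direction of the change in this assay. The iodo-bearing core of compound 1 is weak here and compound 3, with a different amide chain, is weak as well, which gives no reason to expect a large gain.

Compound 4 is therefore expected to remain weak, with an estimated 80000 nM in this assay, between 20000 nM and 300000 nM. That estimate corresponds to an expected at least 1.2-fold lower number from compound 1 to compound 4 (0.09 log units; that floor lies within the scatter).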

Compound 4, half-maximal inhibitory concentration: 11000 nM
Compound 4: middle estimate off by 7.3-fold (0.86 log units), on the high side; the whole stated range lies above it.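

The carbonyl carbon proved to be a place where the read-out in this assay responds to a change, with the iodo group held constant: the exchange of (3-chloropropyl)amino for vinyl gives an at least 9.0-fold lower number from compound 1 to compound 4 (0.95 log units; beyond the scatter). Within the data shown here, until now, the only readable step, an at least 2.8-fold lower number from compound 1 to compound 2 (0.45 log units; beyond the scatter), had concerned the aromatic substituent, so the earlier compounds said nothing about this carbonyl carbon. The full size of the new step cannot be read, because compound 1 stands at a limit and not at a number: the limit of > 100000 nM in this assay, at which 2 of the 4 values shown sit.

The exchange alters several things at once, since vinyl brings a double bond outside aromatic rings and has fewer heavy atoms, while the departing group takes with it a chlorine and a hydrogen-bond donor, and the compounds shown do not separate these; an ethyl group or a plain propylamino group on the same carbonyl carbon would bear on that question. Also open, from the compounds shown here alone, is whether the tert-butyl group of compound 2 and the vinyl group of compound 4 would combine in a single compound, and how the vinyl group would fare with an amine or a carboxylic acid on the aromatic ring in place of iodo.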